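Adding Methylsulfanyl to the Phenyl of Compound 1

The source may hold more compounds than are shown below. What is called first, only, known or untested is meant among the compounds shown, and "the series" means these compounds.

Compound 1 `NS(=O)(=O)c1ccc(-c2oc3ccccc3c(=O)c2-c2ccccc2)cc1`: 61%
Compound 2 `CS(=O)(=O)c1ccc(-c2oc3ccccc3c(=O)c2-c2ccccc2)cc1`: < 5%

Among the measured compounds shown here, in an assay on isolated protein for inhibition of prostaglandin G/H synthase 1 (Mus musculus), tested at 10 ug/mL (on this read-out lower numbers stand for less inhibition and higher numbers for more inhibition at the one concentration tested (going by the name of the read-out)), compound 1 gives 61%, the only true number in the set. Compound 2 is reported only as a limit, < 5%. For the measured compounds named here, the single measured step, a number at least 56 percentage points lower from compound 1 to compound 2 (beyond the scatter), concerns methyl in place of amino on a sulfonyl sulfur and says nothing about the phenyl ring. Compound 3 `CSc1ccc(-c2c(-c3ccc(S(N)(=O)=O)cc3)oc3ccccc3c2=O)cc1` differs from compound 1 by methylsulfanyl in place of hydrogen on an aromatic carbon. Going by the values given here, no measured step touches that place, so the step of a number 6 percentage points lower from compound 1 to compound 3 (within the scatter) is expected to stay within the scatter. Compound 3 is therefore estimated at 55%, between 30% and 75%.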

Compound 3, a percentage reported as inhibition, at one concentration (the size of the read-out at that concentration, not a potency): 90%
Beside the measured number, compound 3's estimate is 35 percentage points below it; the measured number lies above the stated range.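

In this assay, methylsulfanyl in place of hydrogen on an aromatic carbon gives a number 29 percentage points higher from compound 1 to compound 3 (beyond the scatter). Among the compounds shown here, this is the first reading at this position, and it shows that the phenyl ring can carry a group here, para to a large group, with inhibition gained rather than lost. Nothing measured here accounts for that gain.

The compounds shown leave open whether methoxy, chlorine or a longer chain such as ethylsulfanyl at this place would do the same. They also leave open whether the gain survives with methyl in place of amino on the sulfonyl sulfur.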